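This account rests on a few compounds, and the source may have more. Where it says the series, first, only, none or still open, it means among the compounds named here.

Measured so far:
- compound 1, `COc1cc(-c2cc(/C=C/C(=O)c3ccc(N)cc3)[nH]n2)cc(OC)c1OC`: -32%
- compound 2, `COc1ccc(C(=O)/C=C/c2cc(-c3cc(OC)c(OC)c(OC)c3)n[nH]2)cc1OC`: -96%

Both compounds have been run in a functional assay on NCI-H322M cells (Homo sapiens) for cytotoxicity, read by sulforhodamine B assay, with a stated time of 48 h, tested at 10 uM; a higher number here means a weaker effect of the compound at the concentration tested, a lower number a stronger effect. In this assay compound 1 gives -32% and compound 2 gives -96%. For the measured compounds named here, compound 2 stands lowest of the two numbers; its nearest neighbour is compound 1, and the single recorded step, a number 64 percentage points lower from compound 1 to compound 2 (beyond the scatter), is the replacement of 4-aminophenyl by 3,4-dimethoxyphenyl on the carbonyl carbon.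

Compound 3, `COc1ccc(C(=O)/C=C/c2cc(-c3cc(OC)c(OC)c(OC)c3)n[nH]2)cc1`, has not yet been measured. It differs from compound 2 by hydrogen in place of methoxy on an aromatic carbon, the same difference cut one bond further out reading 3,4-dimethoxyphenyl to 4-methoxyphenyl.

Going by the values given here, no measured step concerns the removal of a single methoxy group from this ring; the step from compound 1 to compound 2 exchanges the whole ring and gives no direct guide. Among the compounds with values here, with no pair of the same kind, the expected step of a number 26 percentage points higher from compound 2 to compound 3 (beyond the scatter) from compound 2 to compound 3 is set small and uncertain, leaning toward a somewhat higher number. Compound 3 is therefore estimated at -70% in this assay, with a range from -100% to -25%.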

Compound 3, a percentage reported as activity, at one concentration (the size of the read-out at that concentration, not a potency): -60%
Compound 3: the middle estimate sits 10 percentage points below what was measured, within the range that was stated.
By their numbers in this assay, from the lowest: compound 2; then compound 3; then compound 1.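

In this assay, for the compounds shown here, taking away the methoxy group that stands ortho to a methoxy group and meta to a large group gives a number 36 percentage points higher from compound 2 to compound 3 (beyond the scatter), the first reading of this single position, and it shows that this one group carries a change beyond the scatter. Within the same ring, methoxy in place of amino on an aromatic carbon gives a number 28 percentage points lower from compound 1 to compound 3 (beyond the scatter), so the whole-ring exchange of a number 64 percentage points lower from compound 1 to compound 2 (beyond the scatter) now divides into two single-place steps, each beyond the scatter, with the 4-methoxyphenyl ring of compound 3 lying between the 4-aminophenyl ring of compound 1 and the 3,4-dimethoxyphenyl ring of compound 2. Nothing available here bears on why the number moves with either change.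

The compounds shown leave open whether the lower number of compound 2 depends on a methoxy group in particular or would also follow from a hydroxy group, an ethoxy group or a fluorine atom on the same aromatic carbon. They also leave open whether a methoxy group at this position would lower the number to a similar extent with an amino group in place of the neighbouring methoxy group.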